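Swapping Ethoxy for Ethoxycarbonyl on a Shared Core

A few compounds are considered here, and "the series" means these few. Any claim that something is new, unique, unknown or untested is made for them only; others in the source may bear on it.

Of the compounds shown here, three built on a shared core have been tested in an assay (Rattus norvegicus) for binding affinity to prostacyclin receptor (Homo sapiens), read by radioligand binding; on this read-out lower numbers stand for stronger inhibition and higher numbers for weaker inhibition. Compound 1 `CC/N=C(\N)NCc1ccc(Sc2ccc(Cl)cc2)cc1` reaches only a limit of the assay there, < 10000 nM, so no number stands for it. Compound 2 `COc1cccc(Sc2ccc(NC3=NCCN3)cc2)c1` gives 398 nM in this assay. Among the measured compounds shown here, compound 3 `CCOc1ccc(Sc2ccc(NC3=NCCN3)cc2)cc1` gives 39.8 nM in this assay, which is the lowest of the two numbers known; the nearest number, that of compound 2, lies beyond the usual scatter above it, so the two compounds are clearly told apart.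

Compound 4 `CCOC(=O)c1ccc(Sc2ccc(NC3=NCCN3)cc2)cc1` has not yet been measured. It differs from compound 3 in one place: ethoxycarbonyl in place of ethoxy on an aromatic carbon. For the measured compounds named here, no measured pair in this set shows a change of this kind, so nothing in the measured steps fixes its size or direction. Judged only from the structural change itself, a modest move towards weaker binding is expected for compound 4 in this assay, an estimated step of a 3.8-fold higher number from compound 3 to compound 4 (0.58 log units; beyond the scatter). Compound 4 is therefore expected to give about 150 nM in this assay, with a likely range running from 30 nM to 800 nM.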

Compound 4, inhibition constant: 50.1 nM
Compound 4: the middle estimate sits 3.0-fold (0.48 log units) above what was measured; the measured number falls inside the stated range.
By their numbers in this assay, from the lowest: compounds 3 and 4 (each within the scatter of the next); then compound 2.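

In this assay, putting ethoxycarbonyl in place of ethoxy on an aromatic carbon, para to a large group, amounts to a 1.3-fold higher number from compound 3 to compound 4 (0.10 log units; within the scatter), so this read-out cannot tell the two compounds apart. Among the compounds shown here, the entering group holds more heavy atoms than the one it replaces and adds a double bond outside the aromatic rings, yet in this pair those differences leave no readable mark on the number, which is the first direct information about this position in the set. Nothing measured here speaks to why the two groups read alike.

As far as these compounds go, whether the same tolerance extends to other groups at this position remains open, since a single pair cannot show how far it reaches: a carboxylic acid, an amine or a longer chain such as butoxy might read like these two or might move the number well beyond the scatter. From the compounds shown here alone, it is also open whether a bare hydrogen at this position would give a number close to these two, which would show how much either group contributes at all.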